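The compounds below may be only part of what the source reports. "The series", "measured", "known", "first", "only" and "open" are said of these compounds alone.

Working notes on a small set of indole-derived compounds tested in a functional assay on MCF7 cells (Homo sapiens) for cytotoxicity, read by MTT assay, with a stated time of 2 days, tested at 0.1 uM; on this read-out lower numbers stand for a stronger effect and higher numbers for a weaker effect at the one concentration tested.

Compound 1 `COc1ccc(-c2cc3cc(-c4ccccc4)cc(C(C)=O)c3[nH]2)cc1` gives 87% in this assay. Compound 2 `COc1ccc(-c2cc3cc(-c4ccc(F)cc4)cc(C(C)=O)c3[nH]2)cc1` carries a single alteration, (fluoro in place of hydrogen on an aromatic carbon), and in this assay compound 2 gives 97.3%; the resulting step is a number 10.3 percentage points higher from compound 1 to compound 2 (beyond the scatter).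

Compound 3 `CC(=O)c1cc(/C=C/c2ccccc2)cc2cc(-c3ccccc3)[nH]c12` belongs to a different core: the difference between the core of compound 3 and the core of compound 1 is not broken down here. In this assay compound 3 gives 99.5%, which lies within the scatter of the value of compound 2 and beyond the scatter of the value of compound 1.

Compound 4 `CC(=O)c1cc(/C=C/c2ccccc2)cc2cc(-c3ccc(F)cc3)[nH]c12` has not yet been measured. Within the data shown here, it differs from compound 3 by fluoro in place of hydrogen on an aromatic carbon, the same kind of change as the one from compound 1 to compound 2, and the place of the change is described in the same words for both pairs. The earlier instance produced a modest rise in the read-out. Since compound 3 already sits near the top of the range, the same kind of change is expected to move the number only slightly, and the step from compound 3 to compound 4 is estimated at a number 1.5 percentage points higher from compound 3 to compound 4 (within the scatter). For compound 4 the expected value in this assay is 101%, with a plausible range from 91% to 111%, resting on the step seen from compound 1 to compound 2 and on the value of compound 3.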

Compound 4, a percentage reported as activity, at one concentration (the size of the read-out at that concentration, not a potency): 98.4%
Estimate against measurement, compound 4: 2.6 percentage points above, and the stated range covers the measured number.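

In this assay, the change from phenyl to 4-fluorophenyl on the core of compound 3 gives a number 1.1 percentage points lower from compound 3 to compound 4 (within the scatter), so on this core the fluoro group brings no readable shift. Set beside the earlier instance of the same change on the core of compound 1, which gave a number 10.3 percentage points higher from compound 1 to compound 2 (beyond the scatter), the two steps cannot be told apart: the same change on two cores in this assay, a number 10.3 percentage points higher (beyond the scatter) from compound 1 to compound 2 and a number 1.1 percentage points lower (within the scatter) from compound 3 to compound 4, 11.4 percentage points apart, within the scatter of two such steps

Among these compounds, this does not show that the change carries over unchanged from one core to the other, nor that its outcome depends on the core: only one step lies beyond the scatter, and two pairs measured at a single concentration give no basis for a rule in either direction.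

The compounds shown leave open what a group other than fluoro, such as chloro, an amine or a carboxylic acid, would do in the same place on the aromatic ring on either core. Also open, as far as these compounds go, is whether the fluoro change would read the same way at other concentrations, since a single-concentration read-out is not a potency.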